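A triazole-linked diterpenoid ester with a hydroxyphenyl cap

This account rests on a few compounds, and the source may have more. Where it says the series, first, only, none or still open, it means among the compounds named here.

Three analogues of one shared core have been tested so far. Compound 1 `C/C(=C\CC/C(C)=C/CC[C@@H]1[C@@]2(C)CCC(=O)C(C)(C)[C@H]2CC[C@@]1(C)O)CC/C=C(\C)C(=O)OCc1cn(C[C@@H]2O[C@H](n3ccc(=O)[nH]c3=O)C[C@H]2O)nn1` carries a nucleoside on the triazole ring; in a functional assay on DU-145 cells (Homo sapiens) for antiproliferative activity, read by MTT assay, with a stated time of 48 h (a higher number here means a weaker inhibitor, a lower number a stronger inhibitor), compound 1 gives 33100 nM. Compound 2 `C/C(=C\CC/C(C)=C/CC[C@@H]1[C@@]2(C)CCC(=O)C(C)(C)[C@H]2CC[C@@]1(C)O)CC/C=C(\C)C(=O)OCc1cn(-c2ccccc2C)nn1` instead carries a 2-methylphenyl on the triazole. In this assay compound 2 reaches only the limit of > 150000 nM, not a number, so it stands at the weak end of what is known. Compound 3 `C/C(=C\CC/C(C)=C/CC[C@@H]1[C@@]2(C)CCC(=O)C(C)(C)[C@H]2CC[C@@]1(C)O)CC/C=C(\C)C(=O)O`, the free acid, likewise reaches only the limit of > 150000 nM in this assay. Two of the three values shown therefore sit at the same limit (the limit of > 150000 nM in this assay, at which 2 of the 3 values shown sit).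

Compound 4 `C/C(=C\CC/C(C)=C/CC[C@@H]1[C@@]2(C)CCC(=O)C(C)(C)[C@H]2CC[C@@]1(C)O)CC/C=C(\C)C(=O)OCc1cn(-c2cccc(O)c2)nn1` is the next candidate. It differs from compound 2 in one place: 3-hydroxyphenyl in place of 2-methylphenyl on an aromatic nitrogen. No step between measured compounds involves this change, so nothing shown sets its size. The estimated step from compound 2 to compound 4 in this assay is an at least 1.2-fold lower number from compound 2 to compound 4 (0.09 log units; that floor lies within the scatter), no more than the scatter would allow. Compound 4 is thus expected to give about 120000 nM, likely between 30000 nM and 300000 nM.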

Compound 4, half-maximal inhibitory concentration: 28400 nM
Compound 4: middle estimate off by 4.2-fold (0.63 log units), on the high side; the whole stated range lies above it.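

The phenyl group on the triazole nitrogen clearly matters in this assay: 3-hydroxyphenyl in place of 2-methylphenyl gives an at least 5.2-fold lower number from compound 2 to compound 4 (0.72 log units; beyond the scatter). Among the earlier compounds only compound 1, with its nucleoside, gave a number, 33100 nM, and compound 4, with a substituted phenyl, now gives one too, 28400 nM. The true size of the step stays unknown because compound 2 gives only a limit, not a number: the limit of > 150000 nM in this assay, at which 2 of the 4 values shown sit.

The compounds shown do not separate the loss of the methyl from the gain of the hydroxyl, since the group and its place on the phenyl ring change together. On these data alone, how an unsubstituted phenyl, a 3-methoxyphenyl or a 3-aminophenyl would behave on this nitrogen stays open.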